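The compounds below may be only part of what the source reports. "The series", "measured", "known", "first", "only" and "open" are said of these compounds alone.

Values in an ADME assay on Huh-7 cells (Homo sapiens) for cytotoxicity, with a stated time of 72 h (a lower number here means that less compound is tolerated, a higher number that more compound is tolerated), each of them a limit and not a number:
compound 1 `COCCn1nc(-c2cccs2)c(O)c(C2=NS(=O)(=O)c3cc(NS(C)(=O)=O)ccc3N2)c1=O`: > 1000 nM
compound 2 `CC(C)CC(C)n1nc(-c2cccs2)c(O)c(C2=NS(=O)(=O)c3cc(NS(C)(=O)=O)ccc3N2)c1=O`: > 33000 nM
compound 3 `CS(=O)(=O)Nc1ccc2c(c1)S(=O)(=O)N=C(c1c(O)c(-c3cccs3)nn(CC3CC3)c1=O)N2`: > 1000 nM

Compound 3 has only a limit, > 1000 nM, so it has no exact place among these compounds. Compound 4 `CS(=O)(=O)Nc1ccc2c(c1)S(=O)(=O)N=C(c1c(O)c(-c3cccs3)nn(CCC3CCC3)c1=O)N2` differs from it in one place, with cyclobutylmethyl in place of cyclopropyl on a saturated chain carbon bound to an aromatic nitrogen.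

The measured steps that bear on this change lie in the same part of the structure. They are a step that the two limits leave unreadable from compound 1 to compound 3 and a step that the two limits leave unreadable from compound 2 to compound 3, and also a step that the two limits leave unreadable from compound 1 to compound 2. None of them has a size that can be read, so they offer no direction for compound 4. All three measured compounds gave only limits in this assay, and the same kind of result is expected here, with no step beyond the scatter. The expected step is a step that the limit leaves unreadable from compound 3 to compound 4. The estimate for compound 4 is 20000 nM, expected to lie between 3000 nM and 60000 nM.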

Compound 4, half-maximal cytotoxic concentration: > 1000 nM
Compound 4 ended at the assay's limit; the forecaster's own chance of this, stated with the estimate: 90%; the middle value lies beyond the limit too.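

In this assay, within the data shown here, compound 4 gives only a limit, as do compound 1, compound 2 and compound 3, so no step from any of them to compound 4 can be read. The compounds shown leave open how much of each is tolerated and whether changing the group on the aromatic nitrogen alters that amount.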